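Bromo to fluoro on the phenylsulfonyl series

The compounds below may be only part of what the source reports. "The series", "measured", "known", "first", "only" and "open" are said of these compounds alone.

- Compound 1 `O=S(=O)(c1ccccc1)c1nc2ccccc2nc1N1CCCC1`: 35800 nM
- Compound 2 `O=S(=O)(c1ccc(Br)cc1)c1nc2ccccc2nc1N1CCCC1`: > 50000 nM, a limit of the assay

In a functional assay on KB cells (Homo sapiens) for cytotoxicity, read by MTT assay, with a stated time of 72 h (on this read-out higher numbers stand for weaker inhibition and lower numbers for stronger inhibition), compound 2 has only a limit, > 50000 nM, and no number. This is the limit of > 50000 nM in this assay, at which 1 of the 2 values shown sits.

Compound 3 `O=S(=O)(c1ccc(F)cc1)c1nc2ccccc2nc1N1CCCC1` carries fluoro in place of bromo on an aromatic carbon.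

Among the compounds with values here, one measured step bears on this change, the bromo in place of hydrogen on the same kind of carbon: an at least 1.3-fold higher number from compound 1 to compound 2 (0.14 log units; that floor lies within the scatter). That step does not separate compound 2 from compound 1, so it gives no firm size for a halogen exchange. In this assay no step beyond the scatter is therefore expected, and any movement is expected to be towards a lower number, near compound 1 at 35800 nM.

The estimated step is an at least 1.2-fold lower number from compound 2 to compound 3 (0.09 log units; that floor lies within the scatter). Compound 3 is expected at 40000 nM, with an estimated range of 22000 nM to 70000 nM.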

Compound 3, half-maximal inhibitory concentration: 30100 nM
Estimate against measurement, compound 3: 1.3-fold (0.12 log units) above, and the stated range covers the measured number.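

In this assay, fluoro in place of hydrogen on this aromatic carbon, para to a large group, gives a 1.2-fold lower number from compound 1 to compound 3 (0.08 log units; within the scatter), so this substitution does not separate the two compounds. The exchange of bromo for fluoro at the same place gives an at least 1.6-fold lower number from compound 2 to compound 3 (0.22 log units; that floor lies within the scatter), which is a floor and not a measured size. Compound 2 stands only as a limit, so this step has no upper end: the limit of > 50000 nM in this assay, at which 1 of the 3 values shown sits.

No substituent shown at this position yet produces a step beyond the scatter, and the actual number for the bromo compound remains unknown. An amine or a carboxylic acid on the same aromatic carbon would show whether the read-out at this position can move at all.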